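Swapping 3-bromobenzyl for 4-(trifluoromethyl)benzyl on a shared core

The source may hold more compounds than are shown below. What is called first, only, known or untested is meant among the compounds shown, and "the series" means these compounds.

Measured in a functional assay on HCT-116 cells (Homo sapiens) for antiproliferative activity, read by MTT assay, with a stated time of 24 h; on this read-out higher numbers stand for weaker inhibition and lower numbers for stronger inhibition:
- compound 1 `COc1cccc(C(=O)Oc2ccc3c(=O)c(-c4cc(OC)c(OC)cc4OC)coc3c2)c1`: > 10000 nM (a limit, not a number)
- compound 2 `COc1cc(OC)c(-c2coc3cc(OCC(=O)c4cccc(C(F)(F)F)c4)ccc3c2=O)cc1OC`: > 10000 nM (a limit, not a number)
- compound 3 `COc1cc(OC)c(-c2coc3cc(OCc4cccc(Br)c4)ccc3c2=O)cc1OC`: 1200 nM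

Among the measured compounds shown here, compound 3 is the only compound here with an actual number. For compound 1 and compound 2 the data give only (the limit of > 10000 nM in this assay, at which 2 of the 3 values shown sit). The next compound, compound 4 `COc1cc(OC)c(-c2coc3cc(OCc4ccc(C(F)(F)F)cc4)ccc3c2=O)cc1OC`, differs from compound 3 by 4-(trifluoromethyl)phenyl in place of 3-bromophenyl on a saturated chain carbon bound to an oxygen on an aromatic ring.

Two measured steps lead to compound 3: an at least 8.3-fold lower number from compound 1 to compound 3 (0.92 log units; beyond the scatter) and an at least 8.3-fold lower number from compound 2 to compound 3 (0.92 log units; beyond the scatter). Both are beyond the scatter, but both start from a limit and both remove a carbonyl-bearing group. For the measured compounds named here, compound 4 keeps the benzyl form of compound 3, so neither step matches this swap, and no measured pair isolates it. The expectation therefore rests on compound 3 at 1200 nM, with no shift beyond the scatter foreseen in this assay, although the range stays wide. The estimated step is a 1.5-fold higher number from compound 3 to compound 4 (0.18 log units; within the scatter). For compound 4 the expected value is 1800 nM, within an estimated range of 400 nM to 6000 nM.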

Compound 4, half-maximal inhibitory concentration: 2440 nM
The estimate for compound 4 lay 1.4-fold (0.13 log units) below the measured number; measured number inside the range.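

In this assay, a second benzyl group on the oxygen on the aromatic ring also gives an actual number, and the swap of 3-bromobenzyl for 4-(trifluoromethyl)benzyl has a modest effect that lies just beyond the scatter: a 2.0-fold higher number from compound 3 to compound 4 (0.31 log units; beyond the scatter). Compound 4 also stands apart from both carbonyl-bearing compounds, as shown by an at least 4.0-fold lower number from compound 2 to compound 4 (0.61 log units; beyond the scatter) and by an at least 4.0-fold lower number from compound 1 to compound 4 (0.61 log units; beyond the scatter), so the separation seen earlier with compound 3 alone now holds for two benzyl groups with different ring substituents. Compound 1 and compound 2 each stand at a limit and not at a number, so these two steps give only a minimum size: the limit of > 10000 nM in this assay, at which 2 of the 4 values shown sit.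

The swap changes both the substituent and its printed ring position, and the compounds shown do not separate the contribution of the bromine-to-trifluoromethyl change from that of the move from 3 to 4. They also leave open how this read-out would respond to a benzyl group carrying an amine or a carboxylic acid, or to a longer chain in place of the single saturated chain carbon bound to the oxygen.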